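This account rests on a few compounds, and the source may have more. Where it says the series, first, only, none or still open, it means among the compounds named here.

Measured compounds:
compound 1 `O=C(Nc1cccc(-n2cc(-c3ccncc3)c(-c3ccc(Cl)c(O)c3)n2)c1)Nc1cccc(C(F)(F)F)c1`: 948 nM
compound 2 `COc1cc(-c2nn(-c3cccc(NC(=O)Nc4cc(C(F)(F)F)cc(C(F)(F)F)c4)c3)cc2-c2ccncc2)ccc1Cl`: 250 nM
compound 3 `COc1cc(-c2nn(-c3cccc(NC(=O)c4cccc(C(F)(F)F)c4)c3)cc2-c2ccncc2)ccc1Cl`: 1230 nM

In a functional assay on PC-3 cells (Homo sapiens) for inhibition, read by sulforhodamine B assay, with a stated time of 48 h (a higher number here means a weaker inhibitor of growth, a lower number a stronger inhibitor of growth), compound 3 gives 1230 nM, the highest of the three numbers shown. Compound 1 lies nearest to it and gives 948 nM, a gap that falls within the scatter of this assay, so the two are not told apart. Compound 2 gives 250 nM, a gap beyond the scatter; compound 2 and compound 3 differ in more than one place, however, so the numbers alone cannot be traced to a single change.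

Compound 4 `COc1cc(-c2nn(-c3cccc(NC(=O)c4ccc(Cl)c(C(F)(F)F)c4)c3)cc2-c2ccncc2)ccc1Cl` has not yet been measured in this assay. It is reached from compound 3 by a single change: chloro in place of hydrogen on an aromatic carbon. Among the measured compounds shown here, no measured pair shows this change, so its effect can only be expected, not read off. The account expects a modest move toward a lower number, one that may not clear the scatter, with the step from compound 3 to compound 4 estimated at a 1.8-fold lower number from compound 3 to compound 4 (0.24 log units; within the scatter). Compound 4 is therefore estimated at 700 nM, with a likely range from 250 nM to 2000 nM.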

Compound 4, concentration for 50% growth inhibition: 1290 nM
For compound 4 the middle estimate is 1.8-fold (0.27 log units) below the measured one; low and high end bracket the measured number.
By their numbers in this assay, from the lowest: compound 2; then compounds 1, 3 and 4 (each within the scatter of the next).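

In this assay the placing of chloro in place of hydrogen on an aromatic carbon, ortho to a trifluoromethyl group and para to a large group, gives a 1.0-fold higher number from compound 3 to compound 4 (0.02 log units; within the scatter), so the two compounds are not told apart. Among the compounds shown here, this is the first single-place comparison, and it shows that 3-(trifluoromethyl)phenyl and 4-chloro-3-(trifluoromethyl)phenyl read alike in this growth measurement. No measured finding is at hand that bears on this result.

Whether this position would read the same with an amine or a carboxylic acid in place of chloro remains open, since chloro is the only group shown there apart from hydrogen. The lower number of compound 2 also stays untraced, as compound 2 differs from the others in more than one place.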